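The source may hold more compounds than are shown below. What is called first, only, known or untested is meant among the compounds shown, and "the series" means these compounds.

Measured so far:
- compound 1 `O=C1N[C@H]2[C@H](CS[C@H]2CCCCCc2cn(Cc3cccc(F)c3)nn2)N1`: > 16000 nM
- compound 2 `O=C1N[C@H]2[C@H](CS[C@H]2CCCCCc2cn(Cc3ccccc3Cl)nn2)N1`: > 16000 nM

Compound 2 `O=C1N[C@H]2[C@H](CS[C@H]2CCCCCc2cn(Cc3ccccc3Cl)nn2)N1` is the parent of the next step. In an assay on isolated protein for inhibition of biotin--protein ligase (Homo sapiens), read by scintillation counting, with a stated time of 10 min (on this read-out higher numbers stand for weaker inhibition and lower numbers for stronger inhibition), compound 2 gives > 16000 nM, which is a limit of the assay and not a number. Compound 1 `O=C1N[C@H]2[C@H](CS[C@H]2CCCCCc2cn(Cc3cccc(F)c3)nn2)N1` likewise gives > 16000 nM in this assay, also a limit. Among the compounds with values here, the step that the two limits leave unreadable from compound 1 to compound 2 therefore cannot be read, and no measured step yields a usable size; the only evidence is the limit of > 16000 nM in this assay, at which 2 of the 2 values shown sit.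

Compound 3 `O=C1N[C@H]2[C@H](CS[C@H]2CCCCCc2cn(Cc3ccc(Cl)cc3)nn2)N1` has not been measured in this assay. It differs from compound 2 by 4-chlorophenyl in place of 2-chlorophenyl on a saturated chain carbon bound to an aromatic nitrogen. Since the two measured analogues sit at the limit (the limit of > 16000 nM in this assay, at which 2 of the 2 values shown sit), compound 3 is most likely to sit there as well; any step that the limit leaves unreadable from compound 2 to compound 3 is expected to stay within scatter or remain unreadable. The estimate for compound 3 is 30000 nM, between 8000 nM and 120000 nM.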

Compound 3, inhibition constant: > 16000 nM
Compound 3 ended at the assay's limit (the forecaster's own chance of this, stated with the estimate: 80%); the middle value does not contradict the limit.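

Compound 1, compound 2 and compound 3 all give only a limit of the assay in this assay, so no step among them can be read: the limit of > 16000 nM in this assay, at which 3 of the 3 values shown sit.

The compounds shown leave open whether choosing 3-fluorophenyl, 2-chlorophenyl or 4-chlorophenyl at this place affects inhibition at all.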